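One Aryl Group Swapped on the Amide Nitrogen

A few compounds are considered here, and "the series" means these few. Any claim that something is new, unique, unknown or untested is made for them only; others in the source may bear on it.

Measured compounds:
- compound 1, `COC(=O)c1ccc(N(Cc2cnc(C3CCCCC3)cn2)C(=O)[C@H]2CCN2S(=O)(=O)c2c(F)c(F)c(F)c(F)c2F)c(F)c1`, gives 8900 nM in a functional assay on MCF7 cells (Homo sapiens) for antiproliferative activity, with a stated time of 72 h; a lower number here means that less compound is needed, a higher number that more compound is needed for the effect.
- compound 2, `CONC(=O)c1ccc(N(Cc2ccc(C3CCCCC3)cn2)C(=O)[C@H]2CCN2S(=O)(=O)c2c(F)c(F)c(F)c(F)c2F)cc1O`, is recorded as "not determined" (no result reported) in this assay, so it has no result there.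

Compound 2 therefore stands without a number of its own. Within the data shown here, the only anchor is compound 1, which shares much of its skeleton with compound 2 but differs from it in two other places, so its value sets only a rough level for the series and says nothing direct about compound 2.

Compound 3, `O=C([C@H]1CCN1S(=O)(=O)c1c(F)c(F)c(F)c(F)c1F)N(Cc1ccc(C2CCCCC2)cn1)c1ccc2c(=O)[nH]cnc2c1`, has not yet been measured. It differs from compound 2 in one place: a group of 11 heavy atoms (8 carbon, 2 nitrogen, 1 oxygen; one six-membered aromatic ring of carbon only, one six-membered aromatic ring with 2 hetero atoms) in place of a group of 12 heavy atoms (8 carbon, 1 nitrogen, 3 oxygen; one six-membered aromatic ring of carbon only), on an amide-type nitrogen. Among the measured compounds shown here, no measured step exists for this change, so the expectation rests on the single value of compound 1 and on the size of the swap; a step of modest size in this assay, toward a lower number, seems plausible, though a change within the scatter cannot be excluded. For compound 3 the expected value in this assay is 4000 nM, with a range from 500 nM to 30000 nM.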

Compound 3, half-maximal effective concentration: 3600 nM
For compound 3 the middle estimate is 1.1-fold (0.05 log units) above the measured one; low and high end bracket the measured number.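

Compound 2 has no number to set against the value of compound 3, so no step can be read between them. Nothing shown here offers an explanation for the value of compound 3. From the compounds shown here alone, what replacing the 3-hydroxy-4-(methoxycarbamoyl)phenyl group on the amide-type nitrogen does to activity remains open.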